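The compounds below may be only part of what the source reports. "The series", "measured", "known", "first", "only" and "open" are said of these compounds alone.

Working notes on the series. Compound 1, `COc1ccc(NC(=O)C(=O)c2cn(C(C)C)c3ccccc23)cn1`, is the reference point. Among the compounds with values here, in a functional assay on FaDu cells (Homo sapiens) for cytotoxicity, read by MTT assay, with a stated time of 72 h (a higher number here means that more compound is tolerated, a lower number that less compound is tolerated), compound 1 gives 85 nM, the lowest of the two numbers known so far; the nearest number belongs to compound 3, `COc1nsc(NC(=O)C(=O)c2cn(C(C)C)c3ccccc23)n1`, which gives 10400 nM. Compound 2, `COc1ccc(NC(=O)C(=O)c2cn(C(C)C)c3c(OC)cccc23)cn1`, sits at a limit of this assay, > 10000 nM, and no number is known for it (the limit of > 10000 nM in this assay, at which 1 of the 3 values shown sits). The two measured steps both run away from compound 1: an at least 110-fold higher number from compound 1 to compound 2 (2.07 log units; beyond the scatter), and a 120-fold higher number from compound 1 to compound 3 (2.09 log units; beyond the scatter).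

Compound 4, `COc1ccc(NC(=O)C(=O)c2cn(CCOC(C)C)c3ccccc23)cn1`, has not been measured. It differs from compound 1 by 2-isopropoxyethyl in place of isopropyl on an aromatic nitrogen. Neither measured step touches the aromatic nitrogen: one alters an aromatic carbon of the core, the other exchanges the group on the amide-type nitrogen. Both were large, but nothing shows how far the group on the aromatic nitrogen can be altered before the number moves, so the measured steps give no direction for this one. The expectation is a step within or close to the scatter, a 2.4-fold higher number from compound 1 to compound 4 (0.37 log units; beyond the scatter), with the wider uncertainty on the higher side. Compound 4 is estimated at 200 nM in this assay, with a range from 50 nM to 1500 nM.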

Compound 4, concentration lethal to 50% of the cells: 211 nM
Compound 4: the middle estimate sits 1.1-fold (0.02 log units) below what was measured; low and high end bracket the measured number.
By their numbers in this assay, from the lowest: compound 1; then compound 4; then compound 3.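

Within the data shown here, the aromatic nitrogen is the first place where a change leaves the number close to that of compound 1: in this assay the exchange of isopropyl for 2-isopropoxyethyl gives a modest step (a 2.5-fold higher number from compound 1 to compound 4 (0.39 log units; beyond the scatter)). The change on the aromatic carbon of the core and the change on the amide-type nitrogen both gave large steps, so this position accepts a group of 6 heavy atoms in place of 3, with an oxygen added, at far smaller cost, although the step still lies beyond the scatter and compound 1 keeps the lowest number. Nothing measured on these compounds gives a reason for this step.

The compounds shown do not separate the length of the chain from its oxygen, which a plain pentyl chain on the aromatic nitrogen would address. They also leave open how the number responds at this position to a smaller group such as methyl, to a 2-(dimethylamino)ethyl group, or to a chain ending in a carboxylic acid.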